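A third methoxy group and cytotoxicity in skin fibroblasts

The source may hold more compounds than are shown below. What is called first, only, known or untested is meant among the compounds shown, and "the series" means these compounds.

Of the compounds shown here, three built on one shared core have been tested in an ADME assay on BJ cells (Homo sapiens) for cytotoxicity, read by MTT assay, with a stated time of 72 h; on this read-out lower numbers stand for stronger inhibition and higher numbers for weaker inhibition. Compound 1 `COc1ccccc1CNc1ncnc2c1ncn2C1CCCCO1` bears one methoxy group on its six-membered aromatic ring of carbon only. In this assay compound 1 gives > 100000 nM, which is a limit of the assay and not a number. Compound 2 `COc1ccc(CNc2ncnc3c2ncn3C2CCCCO2)c(OC)c1` carries two methoxy groups. In this assay compound 2 gives > 25000 nM, again only a limit. Compound 3 `COc1ccc(CNc2ncnc3c2ncn3C2CCCCO2)c(OC)c1OC` carries three methoxy groups. In this assay compound 3 gives > 37500 nM, also a limit. The size of the step that the two limits leave unreadable from compound 1 to compound 2 and of the step that the two limits leave unreadable from compound 2 to compound 3 cannot be read, because of the limit of > 100000 nM in this assay, at which 1 of the 3 values shown sits, the limit of > 25000 nM in this assay, at which 1 of the 3 values shown sits, and the limit of > 37500 nM in this assay, at which 1 of the 3 values shown sits, are each a limit. Compound 2 thus stands only at a limit, and the two other values shown are limits as well.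

Compound 4 `COc1cc(OC)c(CNc2ncnc3c2ncn3C2CCCCO2)c(OC)c1` differs from compound 2 by methoxy in place of hydrogen on an aromatic carbon. The two measured steps that bear on this change are both unreadable, so no step beyond the usual scatter is expected in this assay, and the expected step from compound 2 to compound 4 is a step that the limit leaves unreadable from compound 2 to compound 4. Compound 4 is therefore expected to give about 50000 nM, within a range from 20000 nM to 150000 nM, most probably reported again as a limit.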

Compound 4, half-maximal inhibitory concentration: > 50000 nM
Compound 4 ended at the assay's limit (the forecaster's own chance of this, stated with the estimate: 85%); the middle value sits exactly at the limit.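

In this assay compound 4 gives > 50000 nM, which is a limit of the assay and not a number. Compound 2 also stands only at a limit, so the size of the step between compound 2 and compound 4 cannot be read. The compounds shown leave open whether any added methoxy group changes the read-out in this assay.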